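The source may hold more compounds than are shown below. What is called first, only, known or untested is meant among the compounds shown, and "the series" means these compounds.

Of the compounds shown here, three sharing one core have been measured in a functional assay on cells (Lymphocyte, Homo sapiens) for inhibition, read by flow cytometry, using a membrane potential dye, with a stated time of 16 h, tested at 500 nM; on this read-out lower numbers stand for a weaker effect and higher numbers for a stronger effect at the one concentration tested. Compound 1 `CCCCCCCCCCCCCCCCc1nc(N2CCC2)c(C)c(C)c1O` gives 85%. Compound 3 `CCCCCCCCCCCCCCCCCCCc1c(C)c(N(C)C)nc(C)c1O` gives 64%. Compound 2 `Cc1c(N(C)C)nc(CCCCCCCCCCO)c(O)c1C` gives 50%, the lowest of the three numbers; compound 3 stands nearest to it, higher by a margin beyond the scatter, and compound 1 stands furthest, higher by a margin that is also beyond the scatter. Compound 4 `CCCCCCCCCCCCCCCCCCCc1nc(N(C)C)c(C)c(C)c1O` has not yet been measured in this assay. It differs from compound 2 in one place: nonyl in place of hydroxy on a saturated chain carbon, ten or more bonds along the chain from an aromatic carbon. This change makes compound 4 resemble compound 1 and compound 3, whose chains bear no hydroxy and which give the two higher numbers. Among the compounds with values here, no measured pair shows this exact change, so the size of the step can only be read from those two values. The step expected is a number 20 percentage points higher from compound 2 to compound 4 (beyond the scatter), upward and beyond the scatter, though a smaller move cannot be excluded. Compound 4 is therefore estimated at 70%, within a range from 55% to 85%.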

Compound 4, a percentage reported as activity, at one concentration (the size of the read-out at that concentration, not a potency): 65%
Compound 4: middle estimate off by 5 percentage points, on the high side, and the stated range covers the measured number.
By their numbers in this assay, from the lowest: compound 2; then compounds 3 and 4 (each within the scatter of the next); then compound 1.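

In this assay, putting nonyl in place of hydroxy on a saturated chain carbon, ten or more bonds along the chain from an aromatic carbon, gives a number 15 percentage points higher from compound 2 to compound 4 (beyond the scatter) and this modest step stands beyond the scatter. The earlier compounds shown here offered only values without a matched pair, whereas this pair ties a change in the read-out to this one place on the chain. Nothing among the data shown accounts for the step.

The compounds shown leave open whether an amine or a carboxylic acid at this place on the chain would behave like the hydroxy or like the nonyl. They also leave open whether butyl, as a shorter replacement, or a longer chain than nonyl would give a step of similar size.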